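From a Cyanobenzyl to a Cyclohexylmethyl Side Group

A few compounds are considered here, and "the series" means these few. Any claim that something is new, unique, unknown or untested is made for them only; others in the source may bear on it.

Of the compounds shown here, three that share one core have been measured in an ADME assay for permeability, using PAMPA, with a stated time of 30 min, at pH 7.4; on this read-out higher numbers stand for higher permeability and lower numbers for lower permeability. Compound 1 `COc1cccc(CNCCCNc2ccnc3cc(Cc4ccccc4)ccc23)c1O` gives 23 10^-6 cm/s. Compound 2 `COc1cccc(CNCCCNc2ccnc3cc(Oc4ccccc4)ccc23)c1O` gives 317 10^-6 cm/s. Compound 3 `COc1cccc(CNCCCNc2ccnc3cc(Cc4ccc(C#N)cc4)ccc23)c1O` gives 23 10^-6 cm/s. Compound 3 is level with compound 1 at the digits recorded, and the two together are the lowest of the three numbers; its nearest neighbour is compound 1, with no change at the digits printed from compound 1 to compound 3 (within the scatter), and its furthest is compound 2, with a 14-fold lower number from compound 2 to compound 3 (1.14 log units; beyond the scatter).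

Compound 4 `COc1cccc(CNCCCNc2ccnc3cc(CC4CCCCC4)ccc23)c1O` has not yet been measured. It differs from compound 3 by cyclohexyl in place of 4-cyanophenyl on a saturated chain carbon bound to an aromatic carbon.

The recorded steps touch this change only indirectly. The step of no change at the digits printed from compound 1 to compound 3 (within the scatter) shows that putting a cyano group on the benzyl group left this assay unchanged, so its loss on its own is not expected to move the number. For the measured compounds named here, exchanging the aromatic ring for a saturated one has no counterpart among the measured pairs; the one large step, a 14-fold higher number from compound 1 to compound 2 (1.14 log units; beyond the scatter), concerns a different swap. Going by the values given here, with no direct precedent, the expected step of a 1.5-fold higher number from compound 3 to compound 4 (0.18 log units; within the scatter) is small, at or near the scatter, leaning slightly upward. Compound 4 is therefore estimated at 35 10^-6 cm/s, with a likely range from 12 10^-6 cm/s to 100 10^-6 cm/s.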

Compound 4, apparent permeability: 23 10^-6 cm/s
Beside the measured number, compound 4's estimate is 1.5-fold (0.18 log units) above it, within the range that was stated.
By their numbers in this assay, from the lowest: compounds 1, 3 and 4 (each within the scatter of the next); then compound 2.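

In this assay, a saturated ring does no differently from an aromatic one at this place, on a saturated chain carbon bound to an aromatic carbon: the change gives no change at the digits printed from compound 3 to compound 4 (within the scatter), and without the nitrile it gives no change at the digits printed from compound 1 to compound 4 (within the scatter). The earlier compounds shown here showed only that a nitrile on the benzyl group left the number in place, whereas these steps show that the aromatic ring itself can be replaced by cyclohexyl with no step beyond the scatter, and the large gap to the phenoxy group persists with a 14-fold lower number from compound 2 to compound 4 (1.14 log units; beyond the scatter). Benzyl, 4-cyanobenzyl and cyclohexylmethyl therefore read as one level, with phenoxy the only group shown that stands apart, and no measurement here explains that split.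

The compounds shown leave open whether the high number of compound 2 goes with phenoxy as a whole or would also appear with another group joined through oxygen, such as cyclohexyloxy. They also leave open whether the level shared by the other three would hold for a side group carrying an amine or a carboxylic acid, or for a longer chain.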